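Formyl to imine on the indole series: compound 3 outlook

The source may hold more compounds than are shown below. What is called first, only, known or untested is meant among the compounds shown, and "the series" means these compounds.

Measured so far:
Compound 1 `COc1ccc(-c2[nH]c3ccc(C)cc3c2C=O)cc1` – 86 nM
Compound 2 `CCCCCc1ccc2[nH]c(-c3ccc(OC)cc3)c(C=O)c2c1` – 5.5 nM

Both numbers come from a functional assay on MDA-MB-231 cells (Homo sapiens) for antiproliferative activity, with a stated time of 4 days; a higher number here means a weaker inhibitor, a lower number a stronger inhibitor. Among the compounds with values here, compound 2 stands lowest of the two values; the only neighbour is compound 1, and the step from it is a 16-fold lower number from compound 1 to compound 2 (1.19 log units; beyond the scatter), which concerns the pentyl chain on the shared core and nothing at the carbonyl position.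

Compound 3 `CCCCCc1ccc2[nH]c(-c3ccc(OC)cc3)c(/C=N\C)c2c1` is the next member, differing from compound 2 only at the formyl group: a group of 3 heavy atoms (2 carbon, 1 nitrogen; no ring) in place of a group of 2 heavy atoms (1 carbon, 1 oxygen; no ring), on an aromatic carbon. The formyl leaves, and a group of 2 carbon and 1 nitrogen with 1 double bond outside aromatic rings enters on the same aromatic carbon of the five-membered ring of the fused system. Within the data shown here, the one measured step does not touch this place, so no measured step bears directly on it; the series gives no precedent for exchanging the oxygen of the formyl for a nitrogen-bearing group. The expectation is therefore a step without firm direction, and compound 3 is estimated as a 2.7-fold higher number from compound 2 to compound 3 (0.44 log units; beyond the scatter), a value of 15 nM in this assay with a range from 3 nM to 80 nM.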

Compound 3, half-maximal inhibitory concentration: 6 nM
The estimate for compound 3 lay 2.5-fold (0.40 log units) above the measured number; low and high end bracket the measured number.
By their numbers in this assay, from the lowest: compounds 2 and 3 (each within the scatter of the next); then compound 1.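

In this assay, within the data shown here, the formyl on the aromatic carbon of the five-membered ring gives way to the group of 3 heavy atoms (2 carbon, 1 nitrogen) with a 1.1-fold higher number from compound 2 to compound 3 (0.04 log units; within the scatter) and this is the first reading at this position, since the earlier step concerned only the chain on the shared core. With the pentyl chain in place, the formyl is therefore not needed for a low number in this assay, and its oxygen can be replaced by a nitrogen bearing a further carbon without a change that stands out from the scatter, although this rests on a single replacement. No supporting data are at hand to explain why the two groups read alike here.

On these data alone, it remains open whether the same exchange reads alike on the core of compound 1, which carries a methyl group where compound 2 carries the pentyl chain. As far as these compounds go, it also remains open how this position responds to a nitrile, a hydroxymethyl group, a carboxylic acid, or a longer chain on the imine nitrogen.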